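This account rests on a few compounds, and the source may have more. Where it says the series, first, only, none or still open, it means among the compounds named here.

Measured so far:
Compound 1, `COc1ccc(-c2cc3ccccc3c(-c3ccc(O)cc3)n2)cc1`, in an ADME assay on MCF-10A cells (Homo sapiens) for cytotoxicity, read by CCK-8 assay and cell counting, with a stated time of 72 h (a lower number here means a stronger inhibitor, a higher number a weaker inhibitor), gives > 50000 nM, which is a limit of the assay and not a number.
Compound 2, `COc1cc(OC)cc(-c2cc3ccccc3c(-c3cccc(O)c3)n2)c1`, in this assay gives 6770 nM.

Going by the values given here, compound 2 is the only one with a number here; the other value is a limit, as noted under (the limit of > 50000 nM in this assay, at which 1 of the 2 values shown sits). Among the compounds with values here, compound 2 and compound 1 differ in two places at once, so no single step between them can be read.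

Compound 3, `COc1cc(OC)cc(-c2cc3ccccc3c(-c3ccc(O)cc3)n2)c1`, is not yet measured. It differs from compound 2 in 4-hydroxyphenyl in place of 3-hydroxyphenyl on an aromatic carbon, the two having the same atoms joined differently. Compound 3 thus carries the same 4-hydroxyphenyl group as compound 1, whose value in this assay is only a limit. Within the data shown here, no step between measured compounds is available to size this change. A step from compound 2 to compound 3 of a 2.2-fold higher number from compound 2 to compound 3 (0.35 log units; beyond the scatter) toward weaker inhibition is expected, and with it a real chance that only a limit is returned. Compound 3 is estimated at 15000 nM, with a range from 5000 nM to 50000 nM.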

Compound 3, half-maximal inhibitory concentration: 7280 nM
Estimate against measurement, compound 3: 2.1-fold (0.31 log units) above, and the stated range covers the measured number.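

In this assay, 4-hydroxyphenyl in place of 3-hydroxyphenyl on the aromatic carbon next to the ring nitrogen gives a 1.1-fold higher number from compound 2 to compound 3 (0.03 log units; within the scatter), so the two isomeric groups cannot be told apart at this position in this pair. The 4-hydroxyphenyl group therefore does not by itself lead to a limit, as compound 3 returns a number on the core it shares with compound 2. Compound 1 carries the same 4-hydroxyphenyl group, and its value is a limit and not a number: the limit of > 50000 nM in this assay, at which 1 of the 3 values shown sits.

Open, going by these compounds, is how a plain phenyl, an aminophenyl or a carboxyphenyl group would read at this position in this assay, and so whether the hydroxyl group counts for anything there beyond its place on the ring. Going by these compounds alone, also open is what the methoxy groups on the other aromatic ring contribute, as no single step from compound 1 to either of the other two compounds can be read.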